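This account rests on a few compounds, and the source may have more. Where it says the series, first, only, none or still open, it means among the compounds named here.

Compound 3 `CCCCCCOP(=O)(O)OCCSC(=S)N1CCCC1` is measured in a functional assay on MCF7 cells (Homo sapiens) for inhibition, read by MTT assay, with stated times of 18 h and 4 h (on this read-out higher numbers stand for weaker inhibition and lower numbers for stronger inhibition), where compound 3 gives 100000 nM. Among the three compounds measured it has the highest number. Compound 1 `CCCOP(=O)(O)OCCSC(=S)N1CCCC1` gives 73000 nM, and the step of a 1.4-fold higher number from compound 1 to compound 3 (0.14 log units; within the scatter) lies within the scatter. Compound 2 `CCCCCCOP(=O)(O)OCCSC(=S)N1CCN(C)CC1` gives 58000 nM, and the step of a 1.7-fold higher number from compound 2 to compound 3 (0.24 log units; within the scatter) also lies within the scatter. The three measured compounds therefore cannot be told apart on this read-out.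

Compound 4 `CCCCCCCCCCCCCCCCOP(=O)(O)OCCSC(=S)N1CCCC1` is not yet measured. It differs from compound 3 in one place: decyl in place of hydrogen on a saturated chain carbon, six bonds along the chain from an oxygen on an unsaturated carbon. Going by the values given here, the only measured step that bears on this change is the one that lengthens the same chain, a 1.4-fold higher number from compound 1 to compound 3 (0.14 log units; within the scatter), which stayed within the scatter. The change to compound 4 lengthens the chain much further than that step did, so the expectation rests on a single small precedent. The expected step is a 1.3-fold lower number from compound 3 to compound 4 (0.10 log units; within the scatter), which lies within the scatter. Compound 4 is therefore estimated at 80000 nM in this assay, with a range from 25000 nM to 250000 nM.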

Compound 4, half-maximal inhibitory concentration: 72000 nM
Compound 4: the middle estimate sits 1.1-fold (0.05 log units) above what was measured; the measured number falls inside the stated range.
By their numbers in this assay, from the lowest: compounds 2, 4, 1 and 3 (each within the scatter of the next).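

In this assay, the decyl group, with its 10 carbon atoms, gives a 1.4-fold lower number from compound 3 to compound 4 (0.14 log units; within the scatter), so even this large addition to the chain does not move the number beyond the scatter. Before this result, the only evidence on this chain was the much smaller change of a 1.4-fold higher number from compound 1 to compound 3 (0.14 log units; within the scatter); together, the two steps show no sensitivity to chain length at this position among compounds 1, 3 and 4. Nothing measured alongside these compounds speaks to what lies behind this flat result.

Going by these compounds, it remains open whether a chain carrying an amine or a carboxylic acid would give a step beyond the scatter. On these data alone, it is also open whether the decyl change would give the same small step with the 4-methylpiperazin-1-yl group of compound 2 in place of pyrrolidin-1-yl.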